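Notes on amide ring variation, compounds 1 to 4

A few compounds are considered here, and "the series" means these few. Any claim that something is new, unique, unknown or untested is made for them only; others in the source may bear on it.

Measured so far in an ADME assay on HepG2 cells (Homo sapiens) for inhibition, with a stated time of 48 h; a lower number here means that less compound is needed, a higher number that more compound is needed for the effect:
Compound 1 `CC(C(=O)N1CC2CC2C1)N1CCN(S(=O)(=O)c2ccc(C(C)(C)C)cc2)CC1` gives > 40000 nM in this assay, a limit.
Compound 2 `C[C@H](C(=O)N1CCCCC1)N1CCN(S(=O)(=O)c2ccc(C(C)(C)C)cc2)CC1` gives > 40000 nM in this assay, a limit.
Compound 3 `CC(C(=O)N1CCCCCC1)N1CCN(S(=O)(=O)c2ccc(C(C)(C)C)cc2)CC1` gives > 40000 nM in this assay, a limit.

Among the compounds with values here, compound 3 stands at the limit of this assay; the two other values shown sit at the same limit, so no compound can be placed above or below another on these numbers. Within the data shown here, the one measured step, a step that the two limits leave unreadable from compound 1 to compound 3, runs between two limits and its size cannot be read. Among the measured compounds shown here, the only evidence on this series is therefore (the limit of > 40000 nM in this assay, at which 3 of the 3 values shown sit).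

Compound 4 `CC(C(=O)N1CCN(C)CC1)N1CCN(S(=O)(=O)c2ccc(C(C)(C)C)cc2)CC1` differs from compound 3 in one place: 4-methylpiperazin-1-yl in place of azepan-1-yl on a carbonyl carbon. For the measured compounds named here, no measured step speaks to this change, and the step from compound 1 to compound 3 gives no readable size. Given that every value shown sits at the limit, compound 4 is expected to sit there as well, and the step of a number no higher from compound 3 to compound 4 (the limit leaves the size open) is estimated to be no change beyond the scatter. Compound 4 is estimated at 40000 nM in this assay, with a range from 15000 nM to 150000 nM, and most probably the assay will again report only a limit.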

Compound 4, half-maximal effective concentration: > 40000 nM
Compound 4: no number, only a limit; the forecaster's own chance of this, stated with the estimate: 85%; the middle value sits exactly at the limit.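

No step can be read from compound 3 to compound 4 or from compound 1 to compound 4, as both ends of each are limits: the limit of > 40000 nM in this assay, at which 4 of the 4 values shown sit.

Left open is whether the amide rings of compound 1, compound 2, compound 3 and compound 4 differ at all in this assay, and in which direction.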